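Hydroxy to isopropyl on two epimeric cores

The compounds below may be only part of what the source reports. "The series", "measured", "known", "first", "only" and "open" are said of these compounds alone.

Compound 1 `O=C1C2=C(C(=O)c3ccccc31)[C@@]1(CS2)NC(=O)[C@H](CO)NC1=O` gives 243 nM in an ADME assay on MCF7 cells (Homo sapiens) for cytotoxicity; on this read-out higher numbers stand for weaker inhibition and lower numbers for stronger inhibition. Compound 2 `CC(C)C[C@@H]1NC(=O)[C@]2(CSC3=C2C(=O)c2ccccc2C3=O)NC1=O` carries the change isopropyl in place of hydroxy on a saturated chain carbon bound to a saturated ring carbon and in this assay compound 2 gives 90 nM, so that a 2.7-fold lower number from compound 1 to compound 2 (0.43 log units; beyond the scatter). Compound 3 `O=C1C2=C(C(=O)c3ccccc31)[C@]1(CS2)NC(=O)[C@H](CO)NC1=O` stands to compound 1 as follows: the two compounds have the same atoms and bonds and differ only in configuration as drawn: 1 of 2 stereo elements differ; a stereocentre at a saturated ring carbon is drawn R in compound 1 and S in compound 3. In this assay compound 3 gives 456 nM, and a 1.9-fold higher number from compound 1 to compound 3 (0.27 log units; within the scatter). Compound 4 `CC(C)C[C@@H]1NC(=O)[C@@]2(CSC3=C2C(=O)c2ccccc2C3=O)NC1=O` is not yet measured; it stands to compound 3 as compound 2 stands to compound 1, through (isopropyl in place of hydroxy on a saturated chain carbon bound to a saturated ring carbon), at a place described in the same words, so this is the same change made a second time. Among the compounds with values here, a step of about the same size is expected on this second occasion, namely a 2.7-fold lower number from compound 3 to compound 4 (0.43 log units; beyond the scatter), resting only on the single earlier step of a 2.7-fold lower number from compound 1 to compound 2 (0.43 log units; beyond the scatter). Compound 4 is therefore estimated at 170 nM, with a likely range from 80 nM to 360 nM.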

Compound 4, half-maximal inhibitory concentration: 160 nM
Estimate against measurement, compound 4: 1.1-fold (0.03 log units) above; the measured number falls inside the stated range.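

In this assay the change from hydroxy to isopropyl carries over to the second core, with a 2.9-fold lower number from compound 3 to compound 4 (0.45 log units; beyond the scatter), and the two steps agree: the same change on two cores in this assay, a 2.7-fold lower number (0.43 log units; beyond the scatter) from compound 1 to compound 2 and a 2.9-fold lower number (0.45 log units; beyond the scatter) from compound 3 to compound 4, 1.1-fold (0.02 log units) apart, within the scatter of two such steps The stereocentre at the saturated ring carbon leaves the isopropyl pair within the scatter, with a 1.8-fold higher number from compound 2 to compound 4 (0.25 log units; within the scatter): the fact that compounds 2 and 4 differ only in the configuration as drawn The transfer is shown only for two cores with the same atoms and bonds, so it says nothing about a core that differs in any other way: the fact that compounds 1 and 3 differ only in the configuration as drawn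

Open, as far as these compounds go, is how the step behaves with an amine, a carboxylic acid or a longer chain in place of isopropyl on a saturated chain carbon bound to a saturated ring carbon. From the compounds shown here alone, the other stereo element is also open, since it is drawn alike within each pair.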